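Moving the amino group from one phenyl position to another

A few compounds are considered here, and "the series" means these few. Any claim that something is new, unique, unknown or untested is made for them only; others in the source may bear on it.

Compound 2 `COC(=O)c1sc2cc(-c3ccccc3N)cnc2c1N`: 3800 nM
Compound 1 `COC(=O)c1sc2cc(-c3ccsc3)cnc2c1N`: 12400 nM

In a functional assay on NCI-H460 cells (Homo sapiens) for inhibition, read by sulforhodamine B assay, with a stated time of 48 h (a lower number here means a stronger inhibitor of growth, a higher number a weaker inhibitor of growth), compound 2 gives the lowest of the two numbers, its nearest neighbour being compound 1 with 12400 nM. Compound 3 `COC(=O)c1sc2cc(-c3cccc(N)c3)cnc2c1N` differs from compound 2 by 3-aminophenyl in place of 2-aminophenyl on an aromatic carbon. Within the data shown here, the only measured step, a 3.3-fold lower number from compound 1 to compound 2 (0.51 log units; beyond the scatter), swaps the whole aryl group rather than the position of the amino group, so it bears on this step only loosely. A step within the scatter is expected, a 1.2-fold higher number from compound 2 to compound 3 (0.07 log units; within the scatter). Compound 3 is therefore estimated at 4500 nM, within 1500 nM to 13000 nM.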

Compound 3, concentration for 50% growth inhibition: > 150000 nM
Compound 3 was reported as a limit; the forecaster's own chance of this, stated with the estimate: 5%; at least 33-fold (1.52 log units) between middle value and limit.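

In this assay, compound 3 is reported only as a limit, > 150000 nM. Moving the amino group alone gives an at least 39-fold higher number from compound 2 to compound 3 (1.59 log units; beyond the scatter), far larger than the swap of the whole aryl group, a 3.3-fold lower number from compound 1 to compound 2 (0.51 log units; beyond the scatter), so at this position the place of the amino group on the phenyl ring matters greatly. Replacing thiophen-3-yl with 3-aminophenyl gives an at least 12-fold higher number from compound 1 to compound 3 (1.08 log units; beyond the scatter), so the amino group alone does not bring the lower number seen with compound 2. On these data alone, whether a hydroxyl or a methoxy group could stand in for the amine of 2-aminophenyl stays open. So does the true value of compound 3.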